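The source may report more compounds than this note shows. Statements on the series, on what has been measured and on what is new or still open speak of the compounds shown alone.

Working notes on the series around compound 2. Of the compounds shown here, three have been measured in an assay on HEK293 cells for agonist activity at transient receptor potential cation channel subfamily M member 8 (Homo sapiens), read by fluorescence and calcium flux, with a stated time of 15 min; on this read-out lower numbers stand for an effect already at smaller amounts and higher numbers for an effect only at larger amounts of compound. Compound 1 `CCN(Cc1cccs1)C(=O)C(C)Oc1ccc(C)cc1` gives 889 nM. Compound 2 `Cc1ccc(OCC(=O)N(Cc2cccs2)c2nccs2)cc1` gives 2240 nM. Compound 3 `CCN(Cc1cccn1C)C(=O)COc1ccc(C)cc1` gives 21300 nM. Compound 2 thus holds the second highest number of the three: compound 1 sits lower, beyond the scatter, and compound 3 sits higher, also beyond the scatter. The next compound, compound 4 `Cc1ccc(OCC(=O)N(Cc2cccs2)c2ncccn2)cc1`, differs from compound 2 in one place: pyrimidin-2-yl in place of 1,3-thiazol-2-yl on an amide-type nitrogen. Within the data shown here, no measured pair shows such a change, so nothing here fixes its size or direction. The step of a 1.3-fold higher number from compound 2 to compound 4 (0.13 log units; within the scatter) is expected to stay within the usual scatter. For compound 4 in this assay the estimate is 3000 nM, with a range from 1000 nM to 9000 nM.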

Compound 4, half-maximal effective concentration: 3700 nM
Compound 4: middle estimate off by 1.2-fold (0.09 log units), on the low side; low and high end bracket the measured number.
By their numbers in this assay, from the lowest: compound 1; then compounds 2 and 4 (each within the scatter of the next); then compound 3.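

This position now has its first measured change: the step of a 1.7-fold higher number from compound 2 to compound 4 (0.22 log units; within the scatter) is within the scatter. On an amide-type nitrogen, pyrimidin-2-yl in place of 1,3-thiazol-2-yl therefore gives no resolved difference, and a six-membered aromatic ring with 2 hetero atoms fits here as well as a five-membered one. Nothing available accounts for this outcome. Still open, on these data alone, is whether a phenyl ring, or a group carrying a carboxylic acid, would keep the number in this range at the same place. A single pair also leaves open whether this swap behaves alike on the cores of compound 1 and compound 3.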